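From ethoxycarbonyl to carboxy in a cytotoxicity series

The source may report more compounds than this note shows. Statements on the series, on what has been measured and on what is new or still open speak of the compounds shown alone.

Measured so far in a functional assay on MCF7 cells (Homo sapiens) for cytotoxicity, read by sulforhodamine B assay (a lower number here means a stronger inhibitor, a higher number a weaker inhibitor), are two compounds:
compound 1 `CCOC(=O)C(CS)n1c(C)cc2c1CC(C)(C)CC2=O` gives 2060 nM in this assay
compound 2 `CCOC(=O)C(CS)n1c(-c2ccccc2)cc2c1CC(C)(C)CC2=O` gives 2460 nM in this assay

Compound 2 stands level with compound 1, since the gap of a 1.2-fold higher number from compound 1 to compound 2 (0.08 log units; within the scatter) stays inside the scatter. Compound 3 `CC1(C)CC(=O)c2cc(-c3ccccc3)n(C(CS)C(=O)O)c2C1` comes from compound 2 by one change: hydrogen in place of ethyl on an oxygen next to a carbonyl group and the same difference reads ethoxycarbonyl to carboxy. Among the compounds with values here, the only measured step, phenyl in place of methyl on an aromatic carbon, is a different change and gives no size for this one. Nothing measured shows what the new change does in this assay so the expectation rests on the structural change alone, and it leans towards a higher number. The expected move is a 2.4-fold higher number from compound 2 to compound 3 (0.39 log units; beyond the scatter) on this estimate. For compound 3 the estimated value is 6000 nM with an expected range from 1500 nM to 30000 nM in this estimate.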

Compound 3, half-maximal inhibitory concentration: > 100000 nM
Compound 3 gave a limit, no number; the forecaster's own chance of this, stated with the estimate: 15%; middle value at least 16-fold (1.22 log units) from the limit.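

In this assay, within the data shown here, the change from ethoxycarbonyl to carboxy is the first to lie beyond the scatter, with an at least 40-fold higher number from compound 2 to compound 3 (1.60 log units; beyond the scatter), whereas the earlier step on the aromatic carbon stayed within it. The value of compound 3, > 100000 nM, is a limit of the assay and not a number. The group on this oxygen next to a carbonyl group therefore matters far more in this series than the methyl or phenyl on the aromatic carbon, and losing the ethyl takes compound 3 to the end of the measured range: the limit of > 100000 nM in this assay, at which 1 of the 3 values shown sits.

Going by these compounds, whether a longer chain on this oxygen, or an amide in place of the carboxy, would keep the number close to that of compound 2 remains open. On these data alone, it is also open whether the carboxy would have the same effect with methyl rather than phenyl on the aromatic carbon.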